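Bromo substitution on a weak oxazoline series

This account rests on a few compounds, and the source may have more. Where it says the series, first, only, none or still open, it means among the compounds named here.

Compound 1 `C=C[C@@H]1OC(/C=C/c2ccc(Br)cc2)=N[C@H]1CO`: 22000 nM
Compound 2 `C=C[C@@H]1OC(/C=C/c2ccccc2)=N[C@H]1CO`: 40000 nM
Compound 3 `C=C[C@@H]1OC(c2ccccc2)=N[C@H]1CO`: > 4000000 nM

In an assay on isolated protein for inhibition of matrix metalloproteinase-9 (Homo sapiens) (on this read-out lower numbers stand for stronger inhibition and higher numbers for weaker inhibition), compound 2 gives 40000 nM and compound 1 gives 22000 nM; the change from compound 2 to compound 1 is bromo in place of hydrogen on an aromatic carbon, and it made a 1.8-fold lower number from compound 2 to compound 1 (0.26 log units; within the scatter). For compound 3 the value > 4000000 nM is a limit of this assay, not a number. The difference between the core of compound 3 and the core of compound 2 is not broken down here. Compound 4 `C=C[C@@H]1OC(c2ccc(Br)cc2)=N[C@H]1CO` is not yet measured; the change from compound 3 to compound 4 is bromo in place of hydrogen on an aromatic carbon. This is the same kind of change as that from compound 2 to compound 1, though its place reads "para to a group of 9 heavy atoms" where the earlier one reads "para to a large group". Since that earlier step in this assay lay within the scatter, only a small step is expected from compound 3 to compound 4, namely a step that the limit leaves unreadable from compound 3 to compound 4, resting on the limit of compound 3 in this assay. Compound 4 is therefore estimated at 5000000 nM in this assay, with a range of 1500000 nM to 20000000 nM.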

Compound 4, inhibition constant: 9000 nM
For compound 4 the middle estimate is 560-fold (2.74 log units) above the measured one; the measured number lies below the stated range.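

In this assay, bromo in place of hydrogen on an aromatic carbon gave an at least 440-fold lower number from compound 3 to compound 4 (2.64 log units; beyond the scatter), so the size of this change did not carry over from one core to the other: the same change on two cores in this assay, a 1.8-fold lower number (0.26 log units; within the scatter) from compound 2 to compound 1 and an at least 440-fold lower number (2.64 log units; beyond the scatter) from compound 3 to compound 4, at least 240-fold (2.38 log units) apart, beyond the scatter of two such steps. Compound 3 gives > 4000000 nM, which is a limit of the assay and not a number. The step from it therefore has no exact size, and these two pairs do not show why the cores differ or how the change would behave on a third core: the limit of > 4000000 nM in this assay, at which 1 of the 4 values shown sits.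

The compounds shown leave open whether chloro, methoxy or a carboxylic acid in the place of bromo would follow either step. They also leave open how bromo would behave with a longer chain joining the aromatic ring to the core.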